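Swapping the Aryl Cap: Cytotoxicity Expectation for Compound 4

A few compounds are considered here, and "the series" means these few. Any claim that something is new, unique, unknown or untested is made for them only; others in the source may bear on it.

Three close relatives have been tested in an ADME assay on HeLa cells (Homo sapiens) for cytotoxicity, read by ATP content, with a stated time of 3 days; on this read-out lower numbers stand for higher toxicity in this test and higher numbers for lower toxicity in this test. Compound 1 `Cn1ccc(-n2c(=O)n(Cc3cc4cc(Cl)ccc4n3CCCC#N)c3cnccc32)n1` carries a 1-methyl-1H-pyrazol-3-yl group on a ring nitrogen of the shared core; in this assay compound 1 reaches only the limit of > 50000 nM. Compound 2 `N#CCCCn1c(Cn2c(=O)n(-c3ncccn3)c3ccncc32)cc2cc(Cl)ccc21` carries a pyrimidin-2-yl group in the same place, and compound 2 likewise sits at the limit of > 50000 nM. Compound 3 `CS(=O)(=O)c1ccc(-n2c(=O)n(Cc3cc4cc(Cl)ccc4n3CCCC#N)c3cnccc32)cc1`, with a 4-(methylsulfonyl)phenyl group there, again gives only the limit of > 50000 nM. Because every value sits at the limit of > 50000 nM in this assay, at which 3 of the 3 values shown sit, the steps between them cannot be read: a step that the two limits leave unreadable from compound 1 to compound 2, a step that the two limits leave unreadable from compound 1 to compound 3 and a step that the two limits leave unreadable from compound 2 to compound 3. Compound 3 therefore stands where both its neighbours stand, at the limit, with no number to compare.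

Compound 4 `COc1ccc(-n2c(=O)n(Cc3cc4cc(Cl)ccc4n3CCCC#N)c3cnccc32)cc1C` differs from compound 3 only at that ring nitrogen: 4-methoxy-3-methylphenyl in place of 4-(methylsulfonyl)phenyl on an aromatic nitrogen. Going by the values given here, none of the measured steps tells how large a change such a swap brings in this assay: all three were unreadable, and they show only that three different groups in this position gave no toxicity up to the limit. The expected step is therefore a step that the limit leaves unreadable from compound 3 to compound 4, no movement beyond the scatter. Compound 4 is estimated at 60000 nM, with a range from 25000 nM to 200000 nM, most likely reported again only as a limit.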

Compound 4, half-maximal cytotoxic concentration: > 50000 nM
Compound 4 was reported as a limit; the forecaster's own chance of this, stated with the estimate: 85%; the middle value does not contradict the limit.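

In this assay compound 4 gives > 50000 nM, which is a limit and not a number. The steps linking compound 4 with compound 1, compound 2 and compound 3 cannot be read, because all four compounds share one limit: the limit of > 50000 nM in this assay, at which 4 of the 4 values shown sit. The compounds shown leave open whether any group at this ring nitrogen would give a readable value, and how these four compare with one another.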